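The source may hold more compounds than are shown below. What is called first, only, known or untested is meant among the compounds shown, and "the series" means these compounds.

Going by the values given here, in an ADME assay on microsomes from liver (Homo sapiens) for metabolic stability, read by LC-MS, with a stated time of 10 min (on this read-out higher numbers stand for a more stable compound and lower numbers for a less stable compound), compound 1 `CN(C[C@H]1Cc2c(cccc2N2CCN(C3CC3)CC2)CN1)[C@H]1CCCc2cccnc21` gives 15.5%, the lowest of the three numbers measured so far. On the same read-out, compound 2 `CN(C[C@H]1Cc2c(cccc2N2CCN3CCC[C@H]3C2)CN1)[C@H]1CCCc2cccnc21` gives 36.6% and compound 3 `CN(C[C@H]1Cc2c(cccc2N2CCN3CCC[C@@H]3C2)CN1)[C@H]1CCCc2cccnc21` gives 52.2%. The next change leads to compound 4 `CN(C[C@H]1Cc2c(cccc2N2CCN(c3cccc(C(F)(F)F)c3)CC2)CN1)[C@H]1CCCc2cccnc21` and is 3-(trifluoromethyl)phenyl in place of cyclopropyl on an amine nitrogen in a ring.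

Two measured steps start from compound 1 and also remove the cyclopropyl: the modest a number 21.1 percentage points higher from compound 1 to compound 2 (beyond the scatter) and the large a number 36.7 percentage points higher from compound 1 to compound 3 (beyond the scatter). Both go upward, but neither brings in an aromatic ring, so they bear on compound 4 only loosely. The gap between their end points, a number 15.6 percentage points higher from compound 2 to compound 3 (beyond the scatter), is due to the fact that compounds 2 and 3 differ only in the configuration as drawn, which shows that the size of a step in this region can shift without any change in atoms or bonds.

With no aromatic group yet measured on that nitrogen, only a small rise in this assay is expected, not beyond the scatter. The estimated step is a number 4.5 percentage points higher from compound 1 to compound 4 (within the scatter). For compound 4 the expected value is 20%, with an estimated range of 5% to 45%.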

Compound 4, percent of the compound remaining: 90.3%
The estimate for compound 4 lay 70.3 percentage points below the measured number; measured number above the stated range.
By their numbers in this assay, from the lowest: compound 1; then compound 2; then compound 3; then compound 4.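

Placing 3-(trifluoromethyl)phenyl in place of cyclopropyl on the amine nitrogen in the ring gives, in this assay, a number 74.8 percentage points higher from compound 1 to compound 4 (beyond the scatter), a larger step than the largest seen before, a number 36.7 percentage points higher from compound 1 to compound 3 (beyond the scatter). The earlier compounds shown here all carry saturated groups at this position, whereas this result shows that it can take a six-membered aromatic ring, counting the trifluoromethyl, in place of a three-membered non-aromatic ring of carbon only, with no loss on this read-out and a large gain instead. What lies behind the size of this step cannot be told from the data shown, since the only evidence at hand concerns the configuration of compounds 2 and 3 and does not bear on this change.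

The change brings in the aromatic ring and the trifluoromethyl together, so the compounds shown leave open how much of the step belongs to each, a question that an unsubstituted phenyl or a phenyl bearing a chlorine or a methoxy group in place of the trifluoromethyl would address. Also open, going by these compounds, is whether a ring with a nitrogen in it, such as pyridine, on the same nitrogen would behave like the 3-(trifluoromethyl)phenyl group in this assay.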